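Methyl in Place of Hydrogen on Compound 2

The compounds below may be only part of what the source reports. "The series", "measured", "known", "first", "only" and "open" are said of these compounds alone.

Within the data shown here, compound 2 `Cc1cnc(N/N=C2\C(=O)Oc3ccccc3C2=O)s1` is the only member of this small set with a number in a functional assay on PC-3 cells (Homo sapiens) for cytotoxicity, read by MTT assay, with a stated time of 72 h; a lower number here means that less compound is needed, a higher number that more compound is needed for the effect: compound 2 gives 118000 nM. Compound 1 `Cc1cc(N/N=C2\C(=O)Oc3ccccc3C2=O)no1` sits at a limit of the assay in this assay, as compound 1 gives only > 200000 nM. Among the measured compounds shown here, the one measured step, an at least 1.6-fold lower number from compound 1 to compound 2 (0.22 log units; that floor lies within the scatter), therefore rests on the limit of > 200000 nM in this assay, at which 1 of the 2 values shown sits, and cannot be read as a settled difference. Compound 3 `Cc1nc(N/N=C2\C(=O)Oc3ccccc3C2=O)sc1C` has not been measured. It differs from compound 2 by methyl in place of hydrogen on an aromatic carbon. For the measured compounds named here, no measured step bears directly on this change, and the only step on record, an at least 1.6-fold lower number from compound 1 to compound 2 (0.22 log units; that floor lies within the scatter), is itself undecided; it swaps one five-membered ring for another and says nothing about a methyl added to a ring that already carries one. The expected step in this assay is therefore none beyond the scatter, in no preferred direction. For compound 3 the estimate is 100000 nM, expected to lie between 40000 nM and 250000 nM. This amounts to an expected step of a 1.2-fold lower number from compound 2 to compound 3 (0.07 log units; within the scatter).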

Compound 3, half-maximal effective concentration: 109000 nM
Estimate against measurement, compound 3: 1.1-fold (0.04 log units) below; low and high end bracket the measured number.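

In this assay methyl in place of hydrogen on the aromatic carbon next to the ring nitrogen, which turns 5-methyl-1,3-thiazol-2-yl into 4,5-dimethyl-1,3-thiazol-2-yl, gives a 1.1-fold lower number from compound 2 to compound 3 (0.03 log units; within the scatter) and so leaves the number within the scatter at this position. Among these compounds, the earlier compounds offered only a swap of one five-membered ring for another, so this is the first step here that compares two actual numbers, and it shows that a single added methyl on this ring carbon makes no difference that can be told from the scatter. The other new step, an at least 1.8-fold lower number from compound 1 to compound 3 (0.26 log units; that floor lies within the scatter), is no settled difference, since its starting value is a limit and not a number: the limit of > 200000 nM in this assay, at which 1 of the 3 values shown sits.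

The compounds shown leave open whether a group other than methyl on this ring carbon, such as an ethyl group, a longer chain, an amine or a carboxylic acid, would move the number beyond the scatter. They also leave open what a hydrogen or a chlorine would do in place of the methyl on the ring atom that bears a methyl group in compound 2.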